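Removing one methyl from the dimethoxyphenyl compound

The source may hold more compounds than are shown below. What is called first, only, known or untested is meant among the compounds shown, and "the series" means these compounds.

Measured so far in a physicochemical assay for lipophilicity (on this read-out higher numbers stand for higher lipophilicity and lower numbers for lower lipophilicity), are three compounds:
compound 1 `C[C@H]1CC[C@@H]2[C@@H](OC(=O)[C@]23CC(c2ccccc2Br)=NO3)[C@]2(C)C(=O)C=C[C@@]12O` gives 2.22
compound 2 `C[C@H]1CC[C@@H]2[C@@H](OC(=O)[C@]23CC(c2ccccc2)=NO3)[C@]2(C)C(=O)C=C[C@@]12O` gives 1.41
compound 3 `COc1ccc(C2=NO[C@]3(C2)C(=O)O[C@@H]2[C@H]3CC[C@H](C)[C@]3(O)C=CC(=O)[C@@]23C)cc1OC` gives 1.06

Compound 3 stands lowest of the three at 1.06 with compound 2 nearest and compound 1 furthest. Compound 4 `COc1cc(C2=NO[C@]3(C2)C(=O)O[C@@H]2[C@H]3CC[C@H](C)[C@]3(O)C=CC(=O)[C@@]23C)ccc1O` differs from compound 3 in one place, with hydrogen in place of methyl on an oxygen on an aromatic ring, turning 3,4-dimethoxyphenyl into 4-hydroxy-3-methoxyphenyl. Among the compounds with values here, no measured step makes this exchange. The closest evidence is a number 0.35 log units lower from compound 2 to compound 3 (beyond the scatter) where 3,4-dimethoxyphenyl itself enters in place of phenyl. Two further steps remove bromo (a number 0.81 log units lower from compound 1 to compound 2 (beyond the scatter) and a number 1.16 log units lower from compound 1 to compound 3 (beyond the scatter)) and so bear less on this change. A modest move to a lower number is therefore expected in this assay on the scale of a number 0.35 log units lower from compound 2 to compound 3 (beyond the scatter) though that comparison is indirect. The expected step is a number 0.31 log units lower from compound 3 to compound 4 (beyond the scatter) by this estimate. In this assay the estimate for compound 4 is 0.75 (expected range 0.35 to 1.1).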

Compound 4, partition coefficient: 0.75
For compound 4 middle estimate and measured number coincide at the digits printed; the range from low to high includes it.
By their numbers in this assay, from the lowest: compound 4; then compound 3; then compound 2; then compound 1.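

In this assay, within the data shown here, the exchange is now read directly for the first time: hydrogen in place of methyl on an oxygen on an aromatic ring gives a number 0.31 log units lower from compound 3 to compound 4 (beyond the scatter), so this single methyl alone moves the number beyond the scatter. Set against the other aryl groups, 4-hydroxy-3-methoxyphenyl gives a number 0.66 log units lower from compound 2 to compound 4 (beyond the scatter) when it replaces phenyl and a number 1.47 log units lower from compound 1 to compound 4 (beyond the scatter) when it replaces 2-bromophenyl, which places compound 4 lowest of the four compounds, with all of its steps beyond the scatter. Nothing measured here accounts for the size or direction of these steps.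

As far as these compounds go, it remains open whether removing the methyl from the other methoxy group would give a step of similar size. From the compounds shown here alone, how an ethoxy group, an amine or a carboxylic acid on this aromatic ring would read in this assay also remains open.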